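This account rests on a few compounds, and the source may have more. Where it says the series, first, only, none or still open, it means among the compounds named here.

Compound 1 `Cc1ccccc1-c1nc(CN2CCC(C(=O)NCCCN3CCC(C(C)C)CC3)CC2)c(C)o1`: 396 10^-6 cm/s
Compound 2 `COc1cccc(Br)c1-c1nc(CN2CCC(C(=O)NCCCN3C[C@H](C)C[C@H](C)C3)CC2)c(C)o1`: 245 10^-6 cm/s

In a physicochemical assay for permeability, using PAMPA (on this read-out higher numbers stand for higher permeability and lower numbers for lower permeability), compound 2 stands at the lowest of the two numbers, though the nearest value, that of compound 1, lies within the scatter of it. Compound 3 `Cc1cc(C)cc(-c2nc(CN3CCC(C(=O)NCCCN4C[C@H](C)C[C@H](C)C4)CC3)c(C)o2)c1` differs from compound 2 in one place: 3,5-dimethylphenyl in place of 2-bromo-6-methoxyphenyl on an aromatic carbon. Among the compounds with values here, no step between measured compounds is known here, so the expectation rests on the two values alone. The step of a 1.2-fold higher number from compound 2 to compound 3 (0.09 log units; within the scatter) is expected to be small, within the scatter, with no clear direction. Compound 3 is therefore estimated at 300 10^-6 cm/s, within a range from 150 10^-6 cm/s to 550 10^-6 cm/s.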

Compound 3, apparent permeability: 864 10^-6 cm/s
Compound 3: middle estimate off by 2.9-fold (0.46 log units), on the low side, outside the stated range (above it).
By their numbers in this assay, from the lowest: compounds 2 and 1 (each within the scatter of the next); then compound 3.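

In this assay the move from 2-bromo-6-methoxyphenyl to 3,5-dimethylphenyl, on the aromatic carbon next to the ring nitrogen and next to the ring oxygen, brings a 3.5-fold higher number from compound 2 to compound 3 (0.55 log units; beyond the scatter) with the rest of the molecule unchanged. Within the data shown here, this is the first single-place change available, and it shows that the group at this position alone can shift the read-out beyond the scatter. No measured evidence bears on what lies behind this step. Since the bromine, the methoxy and both methyls all change at once, the compounds shown cannot assign the step to any one of them. Going by these compounds, how an unsubstituted phenyl or a pyridine ring would read at this position also remains open.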